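Chloro removal on the benzylamine of compound 1

The compounds below may be only part of what the source reports. "The series", "measured", "known", "first", "only" and "open" are said of these compounds alone.

Measured compounds:
compound 1, `O=[N+]([O-])c1cc(Cl)ccc1CNc1cc(C(F)(F)F)cc2[nH]ncc12`: 90%
compound 2, `Nc1cccc(CNc2cc(C(F)(F)F)cc3[nH]ncc23)c1`: 68%

Of the compounds shown here, two have been measured in an assay for inhibition of Tryptophan 2,3-dioxygenase (Homo sapiens), with stated times of 10 min and 60 min, tested at 10 uM; on this read-out higher numbers stand for a stronger effect at the one concentration tested and lower numbers for a weaker effect. Compound 1 gives 90%, the highest of the two numbers. Compound 2 gives 68%, which lies below compound 1 by a gap beyond the usual scatter. Within the data shown here, the two measured compounds differ in more than one place, so no single step between them can be read off, and nothing about the chloro group on its own can be taken from them.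

Compound 3, `O=[N+]([O-])c1ccccc1CNc1cc(C(F)(F)F)cc2[nH]ncc12`, is not yet measured. It differs from compound 1 by hydrogen in place of chloro on an aromatic carbon.

Among the measured compounds shown here, with no measured single-point step to lean on, the step in this assay is expected to be a small loss, at most at the edge of the scatter. Compound 3 is expected to give 80% in this assay, with a range from 60% to 95%. The expected step is a number 10 percentage points lower from compound 1 to compound 3 (within the scatter).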

Compound 3, a percentage reported as inhibition, at one concentration (the size of the read-out at that concentration, not a potency): 89%
Compound 3: middle estimate off by 9 percentage points, on the low side; the range from low to high includes it.
By their numbers in this assay, from the lowest: compound 2; then compounds 3 and 1 (each within the scatter of the next).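

In this assay, among these compounds, the step is a number 1 percentage points lower from compound 1 to compound 3 (within the scatter) and gives the first reading of a single change: at this aromatic carbon, meta to a nitro group and para to a large group, hydrogen serves in place of chloro with the read-out unchanged within the scatter. The chloro group is therefore not required for the high inhibition seen at this one concentration, although the percentage is not a potency and could conceal a difference that only a full concentration series would show. No measured evidence explains this tolerance.

From the compounds shown here alone, whether a larger group at the same carbon, such as methoxy or a nitrile, would also be tolerated remains open. Also open, going by these compounds, is what replacing the nitro group with an amine at its own carbon would do, with the rest of compound 3 kept the same.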